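A few compounds are considered here, and "the series" means these few. Any claim that something is new, unique, unknown or untested is made for them only; others in the source may bear on it.

Measured so far in the series:

- compound 1 `CCCCn1ccc(-c2ccc(Oc3ccnc(C)c3)cc2)c(C#N)c1=O`: 398 nM
- compound 2 `CCCCn1ccc(-c2ccc(Oc3cccnc3C)cc2)c(C#N)c1=O`: 347 nM
- compound 3 `CCCCn1ccc(-c2ccc(Oc3ccnc(C)c3)c(Cl)c2)c(C#N)c1=O`: 166 nM

In a functional assay on CHO cells for positive allosteric modulation of metabotropic glutamate receptor 2 (Homo sapiens), read by scintillation counting and GTPgammaS binding, with a stated time of 30 min (a lower number here means that less compound is needed, a higher number that more compound is needed for the effect), compound 3 stands at the lowest of the three numbers; the gap to compound 2 is beyond the scatter, as is the gap to compound 1. Among the compounds with values here, the chloro on the core is the only difference between compound 1 and compound 3, and that step gave a 2.4-fold lower number from compound 1 to compound 3 (0.38 log units; beyond the scatter). Compound 4 `CCCCn1ccc(-c2ccc(Oc3cccnc3C)c(Cl)c2)c(C#N)c1=O` is the unmeasured member; its difference from compound 3 is 2-methylpyridin-3-yl in place of 2-methylpyridin-4-yl on an oxygen on an aromatic ring.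

Within the data shown here, the one measured step that bears on this swap is a 1.1-fold lower number from compound 1 to compound 2 (0.06 log units; within the scatter), made on the core without the chloro. It lies within the scatter. Among the measured compounds shown here, no measured pair shows the same swap on the chloro-bearing core, so the expectation rests on that single step alone. The step expected is therefore a 1.1-fold lower number from compound 3 to compound 4 (0.04 log units; within the scatter), which is none beyond the scatter. Compound 4 is estimated at 150 nM, with a range from 70 nM to 350 nM.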

Compound 4, half-maximal effective concentration: 100 nM
Compound 4: middle estimate off by 1.5-fold (0.18 log units), on the high side, within the range that was stated.
By their numbers in this assay, from the lowest: compounds 4 and 3 (each within the scatter of the next); then compounds 2 and 1 (each within the scatter of the next).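

On the chloro-bearing core, 2-methylpyridin-3-yl in place of 2-methylpyridin-4-yl gives a 1.7-fold lower number from compound 3 to compound 4 (0.22 log units; within the scatter), so in this assay this swap now stays within the scatter on both cores, and the two readings agree: the same change on two cores in this assay, a 1.1-fold lower number (0.06 log units; within the scatter) from compound 1 to compound 2 and a 1.7-fold lower number (0.22 log units; within the scatter) from compound 3 to compound 4, 1.4-fold (0.16 log units) apart, within the scatter of two such steps. Chloro in place of hydrogen, earlier seen only with 2-methylpyridin-4-yl, also holds with 2-methylpyridin-3-yl, giving a 3.5-fold lower number from compound 2 to compound 4 (0.54 log units; beyond the scatter), and the two chloro steps agree as well: the same change on two cores in this assay, a 2.4-fold lower number (0.38 log units; beyond the scatter) from compound 1 to compound 3 and a 3.5-fold lower number (0.54 log units; beyond the scatter) from compound 2 to compound 4, 1.4-fold (0.16 log units) apart, within the scatter of two such steps. Across these four compounds, the chloro accounts for both steps beyond the scatter, the oxygen-linked swap for neither, and no compound goes against this.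

As far as these compounds go, it remains open whether fluoro, methyl or methoxy on that aromatic carbon would give a step like that of chloro. From the compounds shown here alone, it is also open how a longer chain in place of butyl would read.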